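The source may report more compounds than this note shows. Statements on the series, on what has been measured and on what is new or still open speak of the compounds shown alone.

Measured so far in a functional assay on NCI-H23 cells (Homo sapiens) for inhibition, read by sulforhodamine B assay, with a stated time of 48 h, tested at 10 uM; a lower number here means less inhibition of growth, a higher number more inhibition of growth at the concentration tested:

Compound 1 `COc1ccc(-c2nc3sc(-c4ccccc4)cn3n2)cc1`: 28%
Compound 2 `C/C(=N/O)c1ccc(NC(=O)Cn2nc(C(F)(F)F)nc2N)cc1`: 4.46%
Compound 3 `Clc1ccc(-c2cn3nc(-c4ccccc4)nc3s2)cc1`: 33%

At 33%, compound 3 lies within the usual scatter of compound 1, so these two cannot be told apart. Compound 2, at 4.46%, is lower than compound 3 by more than the scatter.

The next compound is compound 4 `COc1ccc(-c2nc3sc(-c4ccc(Cl)cc4)cn3n2)cc1`, which has not yet been measured. It differs from compound 3 by one change: methoxy in place of hydrogen on an aromatic carbon of a six-membered aromatic ring of carbon only, para to a large group (methoxy in place of hydrogen on an aromatic carbon).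

Among the compounds with values here, no measured pair shows this single change, so its size in this assay must be judged indirectly, and the estimate stays wide. Compound 1, at 28%, is the nearest guide and also carries a methoxy group. No shift beyond the scatter, in either direction, is therefore expected. The expected step is a number 2 percentage points lower from compound 3 to compound 4 (within the scatter). The estimated value for compound 4 is 31%, with an expected range from 14% to 50%.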

Compound 4, percent growth inhibition at one concentration: 41.5%
Compound 4: middle estimate off by 10.5 percentage points, on the low side; the range from low to high includes it.
By their numbers in this assay, from the lowest: compound 2; then compounds 1, 3 and 4 (each within the scatter of the next, the first and the last beyond it).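

In this assay, methoxy in place of hydrogen on an aromatic carbon, para to a large group, gives a number 8.5 percentage points higher from compound 3 to compound 4 (within the scatter), so with the chloro group already present, this change makes no clear difference to growth inhibition at the concentration tested. Chloro in place of hydrogen on an aromatic carbon gives a number 13.5 percentage points higher from compound 1 to compound 4 (beyond the scatter), a modest step and the first single change here to go beyond the scatter. Within the data shown here, with only one example of each change, neither step shows how the same change would behave on another compound.

As far as these compounds go, whether an amine, a carboxylic acid or a longer chain such as ethoxy in the methoxy position would move the number beyond the scatter stays open. Nothing shown gives a reason for the size of either step.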